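Arylidene thiazolidinones: swapping naphthalene for fluorophenyl

The compounds below may be only part of what the source reports. "The series", "measured", "known", "first", "only" and "open" are said of these compounds alone.

Measured compounds:
compound 1 `CN(C)c1ccc(/C=C2\S/C(=N\c3nc(-c4ccc(Cl)cc4)cs3)NC2=O)cc1` — 100 nM
compound 2 `O=C1N/C(=N/c2nc(-c3ccc(Cl)cc3)cs2)S/C1=C\c1ccc2ccccc2c1` — 300 nM

Of the compounds shown here, two sharing one core have been tested in a functional assay on MCF7 cells (Homo sapiens) for cytotoxicity, read by MTT assay, with a stated time of 72 h; on this read-out lower numbers stand for stronger inhibition and higher numbers for weaker inhibition. Compound 1 `CN(C)c1ccc(/C=C2\S/C(=N\c3nc(-c4ccc(Cl)cc4)cs3)NC2=O)cc1` gives 100 nM, and compound 2 `O=C1N/C(=N/c2nc(-c3ccc(Cl)cc3)cs2)S/C1=C\c1ccc2ccccc2c1` gives 300 nM. Compound 2 therefore stands at the higher of the two numbers, and the step of a 3.0-fold higher number from compound 1 to compound 2 (0.48 log units; beyond the scatter) separates it from compound 1.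

Compound 3 `O=C1N/C(=N/c2nc(-c3ccc(Cl)cc3)cs2)S/C1=C\c1ccc(F)cc1` has not yet been measured. It differs from compound 2 by 4-fluorophenyl in place of naphthalen-2-yl on a double-bonded chain carbon bound to a double-bonded ring carbon. Among the measured compounds shown here, no measured step matches this change: the only step known, a 3.0-fold higher number from compound 1 to compound 2 (0.48 log units; beyond the scatter), concerns a different pair of groups at the same place, and its size is modest. For the measured compounds named here, the single step known is therefore only a loose guide, and a change in this assay beyond the scatter cannot be argued for in either direction.

Compound 3 is consequently expected to sit close to compound 2, with an estimated step of a 1.3-fold higher number from compound 2 to compound 3 (0.12 log units; within the scatter), and its value in this assay is estimated at 400 nM, within a range of 150 nM to 1500 nM.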

Compound 3, half-maximal inhibitory concentration: > 50000 nM
Compound 3 ended at the assay's limit; the forecaster's own chance of this, stated with the estimate: 5%; middle value at least 120-fold (2.09 log units) from the limit.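

In this assay compound 3 stands at a limit of the assay and not at a number: the limit of > 50000 nM in this assay, at which 1 of the 3 values shown sits. Whereas the one earlier step at this place was modest, 4-fluorophenyl in place of naphthalen-2-yl gives an at least 160-fold higher number from compound 2 to compound 3 (2.22 log units; beyond the scatter), so the group on a double-bonded chain carbon bound to a double-bonded ring carbon can decide between clear activity and none that this read-out can measure. The count of rings alone does not sort the three results: fluoro in place of dimethylamino on an aromatic carbon, with the single aromatic ring kept, gives an at least 500-fold higher number from compound 1 to compound 3 (2.69 log units; beyond the scatter).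

The compounds shown leave open whether the activity of the single-ring series depends on dimethylamino itself, or whether a methoxy group, a morpholine or a plain unsubstituted phenyl at this place would also hold it. They also give no true number for compound 3, so both large steps are lower bounds, and nothing here tells why fluoro fares so differently from dimethylamino.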